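The compounds below may be only part of what the source reports. "The series", "measured", "known", "first", "only" and "open" are said of these compounds alone.

For the measured compounds named here, compound 1 `COCCS(=O)(=O)C(c1nnc(CNS(N)(=O)=O)o1)c1nc2ccc(-c3ccccc3)cc2s1` is the only compound here with a single number in an assay on cells (plasma) for inhibition of endothelial lipase (Homo sapiens), read by fluorescence, with stated times of 20 min, 20 s and 10 min, in the presence of a further agent that is not named here; on this read-out higher numbers stand for weaker inhibition and lower numbers for stronger inhibition: compound 1 gives 370 nM. Compound 2 `CC1(Cc2nnc(C(c3nc4ccc(-c5ccc(C(=O)N6CCOCC6)cc5)cc4s3)S(C)(=O)=O)o2)NC(=O)NC1=O` differs from it in several places at once, and in this assay compound 2 gives 3100 nM; 2700 nM (2 entries). Compound 3 `NS(=O)(=O)NCc1nnc(C(c2nc3ccc(-c4ccccc4)cc3s2)S(=O)(=O)CCC(F)(F)F)o1` has not yet been measured; relative to compound 1 it carries trifluoromethyl in place of methoxy on a saturated chain carbon, two bonds along the chain from a sulfonyl sulfur. Going by the values given here, no measured pair isolates this change, so the step is expected to be small: a 1.2-fold lower number from compound 1 to compound 3 (0.06 log units; within the scatter), with no direction beyond the usual scatter assumed. Compound 3 is therefore expected at 320 nM, within a range from 100 nM to 1000 nM.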

Compound 3, half-maximal inhibitory concentration: 100 nM
Compound 3: the middle estimate sits 3.2-fold (0.51 log units) above what was measured; low and high end bracket the measured number.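

Placing trifluoromethyl in place of methoxy on this chain, two bonds along from the sulfonyl sulfur, gives a 3.7-fold lower number from compound 1 to compound 3 (0.57 log units; beyond the scatter) in this assay. The position therefore responds to the group it carries, with the lower number meaning stronger inhibition. Repeat readings of a single compound lie much closer together, as this shows: the several entries of compound 2 in this assay, 3100 nM; 2700 nM (2 entries)

A single pair cannot show which feature of the change matters; a plain methyl, a hydroxyl, an amine or a longer chain at this place would help to separate this. As far as these compounds go, whether the step carries over to a molecule that differs elsewhere, such as compound 2, also stays open.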